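Trifluoromethyl for Ethoxy on the Arylpiperazine

The source may hold more compounds than are shown below. What is called first, only, known or untested is meant among the compounds shown, and "the series" means these compounds.

Of the compounds shown here, three have been measured in a functional assay for antagonist activity at Alpha-1A adrenergic receptor (Oryctolagus cuniculus); on this read-out lower numbers stand for tighter binding and higher numbers for weaker binding. Compound 1 `CNC(=O)c1cccnc1NCCCN1CCN(c2ccccc2OC)CC1` gives 1 nM in this assay. Compound 2 `COc1ccccc1N1CCN(CCCSc2ccccc2C(=O)N(C)C)CC1` gives 2 nM. Compound 3 `CCOc1ccccc1N1CCN(CCCNc2ncccc2C(=O)N(C)C)CC1` gives 0.501 nM, the lowest of the three numbers; the value of compound 1 sits within the usual scatter of it, while the value of compound 2 lies beyond that scatter. Compound 4 `CN(C)C(=O)c1cccnc1NCCCN1CCN(c2ccccc2C(F)(F)F)CC1` has not yet been measured. It differs from compound 3 in a single place: trifluoromethyl in place of ethoxy on an aromatic carbon. Among the compounds with values here, no pair among the measured compounds isolates this exchange, so nothing measured shows its size directly. The three values cluster at low numbers across several variations of the shared core, which suggests that the core tolerates change, but the exchange here touches a group present in all three measured compounds in one form or another. Compound 4 is therefore expected to give 3 nM in this assay, with a range from 0.8 nM to 12 nM. The expected step of a 6.0-fold higher number from compound 3 to compound 4 (0.78 log units; beyond the scatter) is estimated to run toward a higher number, beyond the scatter.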

Compound 4, dissociation constant: 12.6 nM
Estimate against measurement, compound 4: 4.2-fold (0.62 log units) below, outside the stated range (above it).
By their numbers in this assay, from the lowest: compounds 3, 1 and 2 (each within the scatter of the next, the first and the last beyond it); then compound 4.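

In this assay, trifluoromethyl in place of ethoxy on the aromatic carbon ortho to a large group gives a 25-fold higher number from compound 3 to compound 4 (1.40 log units; beyond the scatter), a large step. Within the data shown here, this is the first single exchange isolated, and it shows that this one place on the arylpiperazine can move the number well beyond the scatter, which the earlier compounds, differing in several places at once, could not show. Nothing measured here bears on why the step is so large.

As far as these compounds go, it remains open whether a fluorine, a methyl group or a hydroxyl on the same aromatic carbon would keep the number close to that of compound 3 or move it toward that of compound 4. From the compounds shown here alone, it is also open whether the same exchange would produce a step of similar size on the thioether chain of compound 2.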